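This account rests on a few compounds, and the source may have more. Where it says the series, first, only, none or still open, it means among the compounds named here.

Working notes on the series. Compound 1, `CN(CCCCn1c(=O)oc2ccccc21)Cc1cccc(Cl)c1`, sits at the lower of the two numbers measured in an assay on membranes from liver for displacement of a labelled ligand from Sigma non-opioid intracellular receptor 1 (Rattus norvegicus), read by scintillation counting (a lower number here means a stronger inhibitor, a higher number a weaker inhibitor), where compound 1 gives 302 nM. Going by the values given here, its only measured companion is compound 2, `CN(CCCn1c(=O)oc2ccccc21)Cc1cccc(Cl)c1`, which in this assay gives 3230 nM; the two values lie beyond the scatter of each other, with compound 2 the higher of the pair. Among the compounds with values here, no computed step between them is available, so only the two values themselves are noted.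

The next compound, compound 3, `Cc1cccc(CN(C)CCCCn2c(=O)oc3ccccc32)c1`, has not yet been measured in this assay. It differs from compound 1 in a single place: methyl in place of chloro on an aromatic carbon, meta to a large group. Compound 1 carries the 3-chlorobenzyl group, compound 3 the 3-methylbenzyl group.

Within the data shown here, no measured pair in this set shows what this exchange does in this assay. The expectation is a small step in the direction of a higher number, probably not beyond the scatter, and the estimate for compound 3 is 450 nM with a range from 150 nM to 1400 nM. The expected step is given by a 1.5-fold higher number from compound 1 to compound 3 (0.17 log units; within the scatter).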

Compound 3, inhibition constant: 102 nM
For compound 3 the middle estimate is 4.4-fold (0.64 log units) above the measured one, outside the stated range (below it).
By their numbers in this assay, from the lowest: compound 3; then compound 1; then compound 2.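

Going by these compounds alone, replacing the 3-chlorobenzyl group with the 3-methylbenzyl group gives the first reading of this position in this assay, with a 3.0-fold lower number from compound 1 to compound 3 (0.47 log units; beyond the scatter), so chloro is not needed at this place for a number at least this low. Within the data shown here, the earlier pair kept this substituent fixed, making this the first sign that the group on this aromatic carbon changes the number, even though chloro and methyl match in the count of heavy atoms and neither carries a hydrogen-bond donor or acceptor. Nothing measured on these compounds accounts for the direction of the step.

Going by these compounds, whether the number follows methyl in particular remains open: hydrogen, fluoro, methoxy, trifluoromethyl or ethyl at this same place would show how far the trend extends beyond this single exchange. The 3-methylbenzyl group is also shown only on the chain of compound 1, so whether the step carries over to the chain of compound 2 is unresolved.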